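Thiophene carboxamides: a nitro-for-methyl swap in a new core

The compounds below may be only part of what the source reports. "The series", "measured", "known", "first", "only" and "open" are said of these compounds alone.

Measured compounds:
compound 1, `Cc1ccc(C(=O)Nc2sc3c(c2C(N)=O)CCN(Cc2ccc(Cl)cc2Cl)C3)cc1`, > 50000 nM
compound 2, `NC(=O)c1c(NC(=O)c2cccc([N+](=O)[O-])c2)sc2c1CCN(Cc1ccc(Cl)cc1Cl)C2`, 33000 nM
compound 3, `Cc1ccc(C(=O)Nc2sc3c(c2C(N)=O)CCN(C(=S)Nc2ccccc2Cl)C3)cc1`, 26300 nM

In a functional assay on HeLa cells (Homo sapiens) for antiproliferative activity, with a stated time of 24 h (on this read-out lower numbers stand for stronger inhibition and higher numbers for weaker inhibition), compound 1 reports only a limit, > 50000 nM, as noted in the limit of > 50000 nM in this assay, at which 1 of the 3 values shown sits. Compound 2 carries 3-nitrophenyl in place of 4-methylphenyl on a carbonyl carbon and in this assay compound 2 gives 33000 nM, which is an at least 1.5-fold lower number from compound 1 to compound 2 (0.18 log units; that floor lies within the scatter). Compound 3 differs from compound 1 in its core, (a group of 10 heavy atoms (7 carbon, 1 nitrogen, 1 sulfur, 1 chlorine; one six-membered aromatic ring of carbon only) in place of a group of 9 heavy atoms (7 carbon, 2 chlorine; one six-membered aromatic ring of carbon only), on an amine nitrogen in a ring), and in this assay compound 3 gives 26300 nM, a step of an at least 1.9-fold lower number from compound 1 to compound 3 (0.27 log units; that floor lies within the scatter); compound 3 and compound 2 sit within the scatter of each other.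

Compound 4, `NC(=O)c1c(NC(=O)c2cccc([N+](=O)[O-])c2)sc2c1CCN(C(=S)Nc1ccccc1Cl)C2`, is not yet measured. It stands to compound 3 as compound 2 stands to compound 1: 3-nitrophenyl in place of 4-methylphenyl on a carbonyl carbon, the same change at the same place. The earlier step gave only a floor within the scatter, so the account expects a small step of a 1.5-fold lower number from compound 3 to compound 4 (0.16 log units; within the scatter), resting on compound 2 and its step of an at least 1.5-fold lower number from compound 1 to compound 2 (0.18 log units; that floor lies within the scatter). Compound 4 is therefore estimated at 18000 nM in this assay, between 6000 nM and 50000 nM.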

Compound 4, half-maximal inhibitory concentration: 40300 nM
Compound 4: middle estimate off by 2.2-fold (0.35 log units), on the low side; the measured number falls inside the stated range.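

In this assay, putting 3-nitrophenyl in place of 4-methylphenyl on the core of compound 3 gives a 1.5-fold higher number from compound 3 to compound 4 (0.19 log units; within the scatter), and the change on the amine nitrogen in a ring, read with 3-nitrophenyl in place, gives a 1.2-fold higher number from compound 2 to compound 4 (0.09 log units; within the scatter). Within the data shown here, this shows no measurable effect of the 3-nitrophenyl change on the core of compound 3, but it does not show whether the change carries over from one core to the other: the same change on two cores in this assay, an at least 1.5-fold lower number (0.18 log units; that floor lies within the scatter) from compound 1 to compound 2 and a 1.5-fold higher number (0.19 log units; within the scatter) from compound 3 to compound 4; the limit leaves it open whether they differ Compound 1 reports only a limit, > 50000 nM, and this is the one value that leaves the comparison unsettled.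

The compounds shown leave open whether another group on the carbonyl carbon, such as an amine, a carboxylic acid or a longer chain in place of the aromatic ring, would give a step beyond the scatter on either core. They also leave open how the 3-nitrophenyl change would read with a third group on the amine nitrogen in a ring, such as a simple methyl.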